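The source may hold more compounds than are shown below. What is called first, only, known or untested is meant among the compounds shown, and "the series" means these compounds.

Three amides that differ only in the group on the carbonyl carbon have been measured in an ADME assay on microsomes (Homo sapiens) for metabolic stability; on this read-out lower numbers stand for a shorter-lived compound and higher numbers for a longer-lived compound. Compound 1 `O=C(C1CCCC1)N1N=CCC1c1ccccc1`, with cyclopentyl, gives 1.13 h. Compound 3 `O=C(C1CCC1)N1N=CCC1c1ccccc1`, with cyclobutyl, gives 1.38 h. That makes a 1.2-fold higher number from compound 1 to compound 3 (0.09 log units; within the scatter), so these two values cannot be told apart. Compound 2 `CC(C)C(=O)N1N=CCC1c1ccccc1`, with isopropyl, gives > 1.5 h, which is a limit of the assay and not a number. The steps involving compound 2 are an at least 1.3-fold higher number from compound 1 to compound 2 (0.12 log units; that floor lies within the scatter) and an at least 1.0-fold lower number from compound 2 to compound 3 (0.03 log units; that floor lies within the scatter).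

Compound 4 `CC(C)(CO)C(=O)N1N=CCC1c1ccccc1` keeps the shared core but has 1-(hydroxymethyl)-1-methylethyl in place of cyclobutyl on the carbonyl carbon: 1-(hydroxymethyl)-1-methylethyl in place of cyclobutyl on a carbonyl carbon. The three measured steps all change this same place, and none leaves the scatter. However, none of them brings in a group like the entering one, so they are only a loose guide. No step beyond the scatter is therefore expected in this assay. The expected size is a 1.1-fold higher number from compound 3 to compound 4 (0.04 log units; within the scatter). Compound 4 is estimated at 1.5 h, with an expected range from 0.9 h to 2.3 h.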

Compound 4, half-life: > 1.5 h
Compound 4: a limit, no number; the forecaster's own chance of this, stated with the estimate: 45%; the middle value sits exactly at the limit.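

This position on the carbonyl carbon tolerates a group with a hydrogen-bond donor and acceptor: in this assay, compound 4, which carries 1-(hydroxymethyl)-1-methylethyl, gives a limit of the assay and not a number, and it shows no visible loss of half-life. Both an at least 1.0-fold higher number from compound 3 to compound 4 (0.03 log units; that floor lies within the scatter) and an at least 1.3-fold higher number from compound 1 to compound 4 (0.12 log units; that floor lies within the scatter) have floors that lie within the scatter, so a real gain cannot be claimed. The step between compound 2 and compound 4 cannot be read because both sit at the same limit: the limit of > 1.5 h in this assay, at which 2 of the 4 values shown sit.

As far as these compounds go, the true half-lives of compound 2 and compound 4 remain unknown, so any effect of adding hydroxymethyl stays hidden. From the compounds shown here alone, it also remains open whether an amine or a carboxylic acid in place of the hydroxymethyl would leave the half-life unchanged.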